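The source may report more compounds than this note shows. Statements on the series, on what has been measured and on what is new or still open speak of the compounds shown alone.

Compound 1 `Cc1ccccc1-c1nc(CN2CCC(C(=O)NCCCN3CCC(C)CC3)CC2)c(C)o1` stands at a limit in an ADME assay on microsomes from liver (Rattus norvegicus) for metabolic stability, read by LC-MS, using NADPH, at 37 degrees C; on this read-out lower numbers stand for a shorter-lived compound and higher numbers for a longer-lived compound: it reads > 0.5 h, which is a limit and not a number. Compound 3 `Cc1ccccc1-c1nc(CN2CCC(C(=O)NCCN3C[C@H](C)C[C@H](C)C3)CC2)c(C)o1` has 3,5-dimethylpiperidin-1-yl in place of (4-methylpiperidin-1-yl)methyl on a saturated chain carbon, two bonds along the chain from an amide-type nitrogen. Compound 2 `Cc1oc(-c2c(Br)cccc2Br)nc1CN1CCC(C(=O)NCCCN2C[C@H](C)C[C@H](C)C2)CC1`, which also carries 3,5-dimethylpiperidin-1-yl, gives 0.035 h in this assay, and this value points towards a shorter half-life. The estimated step of an at least 2.5-fold lower number from compound 1 to compound 3 (0.39 log units; beyond the scatter) is therefore expected to be a shortening beyond the usual scatter. For compound 3 the expected half-life is 0.2 h, with an estimated range of 0.05 h to 0.7 h.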

Compound 3, half-life: > 0.5 h
Compound 3: no number, only a limit; the forecaster's own chance of this, stated with the estimate: 20%; middle value at least 2.5-fold (0.39 log units) from the limit.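

Compound 1 and compound 3 both give limits and not numbers, so no step between them can be read: the limit of > 0.5 h in this assay, at which 2 of the 3 values shown sit.

The compounds shown leave open how far, and in which direction, the half-life of compound 3 differs from that of compound 1 in this assay.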